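This account rests on a few compounds, and the source may have more. Where it says the series, first, only, none or still open, it means among the compounds named here.

In a functional assay on MIA PaCa-2 cells (Homo sapiens) for antiproliferative activity, read by resazurin assay, with a stated time of 70 h (a higher number here means a weaker inhibitor, a lower number a stronger inhibitor), compound 1 (`[O-][S+](CC#Cc1ccccc1C#CCO)c1c(F)c(F)c(F)c(F)c1F`) gives 2600 nM, and compound 2 (`O=S(=O)(CC#Cc1ccccc1C#CCO)c1c(F)c(F)c(F)c(F)c1F`) gives 3900 nM. From the compounds shown here alone, compound 3 (`[O-][S+](CC#Cc1ccccc1C#CCCCCO)c1c(F)c(F)c(F)c(F)c1F`) reaches only a limit of the assay, > 10000 nM, so its true position is unknown. Compound 4 (`[O-][S+](CC#Cc1ccccc1)c1c(F)c(F)c(F)c(F)c1F`) differs from compound 3 by hydrogen in place of 6-hydroxyhex-1-yn-1-yl on an aromatic carbon. Among the compounds with values here, only one measured step bears on this change, and only indirectly: an at least 3.8-fold higher number from compound 1 to compound 3 (0.58 log units; beyond the scatter), which lengthens the chain without removing it. Since the shorter chain of compound 1 gave the lower number, a move toward a stronger inhibitor in this assay is expected, though with little certainty. The expected change is an at least 1.6-fold lower number from compound 3 to compound 4 (0.22 log units; that floor lies within the scatter). For compound 4 the estimated value is 6000 nM, with an expected range from 1500 nM to 20000 nM.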

Compound 4, half-maximal inhibitory concentration: 7800 nM
For compound 4 the middle estimate is 1.3-fold (0.11 log units) below the measured one; measured number inside the range.
By their numbers in this assay, from the lowest: compounds 1, 2 and 4 (each within the scatter of the next, the first and the last beyond it). At a limit, above all of these: compound 3.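

In this assay, hydrogen in place of 3-hydroxyprop-1-yn-1-yl gives a 3.0-fold higher number from compound 1 to compound 4 (0.48 log units; beyond the scatter), so the shorter arm goes with a lower number than no arm, though compound 4 stays measurable without one. Hydrogen in place of 6-hydroxyhex-1-yn-1-yl gives an at least 1.2-fold lower number from compound 3 to compound 4 (0.10 log units; that floor lies within the scatter), so that change shows no clear gain. For compound 3 the number is only a limit: the limit of > 10000 nM in this assay, at which 1 of the 4 values shown sits.

The compounds shown leave open whether an amine or a carboxylic acid in place of the hydroxy on the shorter arm would keep its lower number. They also leave open how a chain of intermediate length would read.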